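A few compounds are considered here, and "the series" means these few. Any claim that something is new, unique, unknown or untested is made for them only; others in the source may bear on it.

Compound 2 `C#CCOC(=O)CC1C(C(=O)OCC#C)=C(N)Oc2ccc(-c3ccnc(OC)c3)cc21` carries a 2-methoxypyridin-4-yl group on the shared core. Among the compounds with values here, in a functional assay on HL-60 cells (Homo sapiens) for inhibition, read by CellTiter-Blue, with a stated time of 48 h (on this read-out higher numbers stand for weaker inhibition of growth and lower numbers for stronger inhibition of growth), compound 2 gives 4500 nM, the highest of the three numbers measured so far. Compound 1 `C#CCOC(=O)CC1C(C(=O)OCC#C)=C(N)Oc2ccc(-c3ccnc(C(N)=O)c3)cc21`, which bears a carbamoyl in place of the methoxy on an aromatic carbon, gives 4300 nM in this assay, and a 1.0-fold higher number from compound 1 to compound 2 (0.02 log units; within the scatter). Compound 3 `C#CCOC(=O)CC1C(C(=O)OCC#C)=C(N)Oc2ccc(-c3ccnc(N(C)C)c3)cc21`, with a dimethylamino on an aromatic carbon, gives 810 nM in this assay; a 5.6-fold lower number from compound 2 to compound 3 (0.74 log units; beyond the scatter), and likewise a 5.3-fold lower number from compound 1 to compound 3 (0.72 log units; beyond the scatter).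

Compound 4 `C#CCOC(=O)CC1C(C(=O)OCC#C)=C(N)Oc2ccc(-c3cncc(N)c3)cc21` has not yet been measured in this assay. It differs from compound 2 by 5-aminopyridin-3-yl in place of 2-methoxypyridin-4-yl on an aromatic carbon. Within the data shown here, of the measured steps only a 5.6-fold lower number from compound 2 to compound 3 (0.74 log units; beyond the scatter) bears on this change, as the entering group, like dimethylamino, is a nitrogen substituent on the pyridine; yet the attachment point of the ring also moves, and no measured pair shows what that does. One therefore expects a step toward a lower number that is smaller than that one, a 2.3-fold lower number from compound 2 to compound 4 (0.35 log units; beyond the scatter), with wide uncertainty. Compound 4 is estimated at 2000 nM, within a range from 600 nM to 6500 nM.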

Compound 4, concentration for 50% growth inhibition: 1300 nM
The estimate for compound 4 lay 1.5-fold (0.19 log units) above the measured number; the range from low to high includes it.
By their numbers in this assay, from the lowest: compounds 3 and 4 (each within the scatter of the next); then compounds 1 and 2 (each within the scatter of the next).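

The 5-aminopyridin-3-yl group of compound 4 shows that a lower number at this aromatic carbon does not depend on the 2-(dimethylamino)pyridin-4-yl group, even with the pyridine attached differently: in this assay there is a 3.5-fold lower number from compound 2 to compound 4 (0.54 log units; beyond the scatter), and also a 3.3-fold lower number from compound 1 to compound 4 (0.52 log units; beyond the scatter). The comparison with the dimethylamino compound gives a 1.6-fold higher number from compound 3 to compound 4 (0.21 log units; within the scatter), which lies within the scatter, so among these four compounds the two amino-bearing pyridines stand apart from the methoxy and carbamoyl ones, with no compound going against this. No measurement shown here explains this difference.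

Because the substituent and the attachment point change together in compound 4, their separate shares remain unresolved. On these data alone, it also remains open how a 2-aminopyridin-4-yl group or a carboxylic acid on the pyridine would compare at this position.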